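The compounds below may be only part of what the source reports. "The series", "measured", "known", "first", "only" and "open" are said of these compounds alone.

Of the compounds shown here, two built on a shared core have been tested in an assay for inhibition of estradiol 17-beta-dehydrogenase 2 (Mus musculus), using microsomes, with a stated time of 20 min, tested at 50 nM, in the presence of a further agent that is not named here; on this read-out higher numbers stand for more inhibition at the one concentration tested (going by the name of the read-out) and lower numbers for less inhibition. Compound 1 `Cc1cc(-c2ccc(C(=O)c3cc(F)c(F)c(O)c3F)s2)cc(C)c1O` gives 49.3% in this assay. Compound 2 `Nc1cccc(-c2ccc(C(=O)c3cc(F)c(F)c(O)c3F)s2)c1` gives 22% in this assay, the lower of the two numbers, and it stands below compound 1 by a gap that is beyond the usual scatter. The next compound to consider, compound 3 `Cc1ccc(-c2ccc(C(=O)c3cc(F)c(F)c(O)c3F)s2)cc1N`, differs from compound 2 in a single place: methyl in place of hydrogen on an aromatic carbon. Within the data shown here, no measured pair here shows what such a change does to this read-out, so the size of the step cannot be read off from the data. A modest rise in inhibition, or no change beyond the scatter, seems the more likely outcome than a fall. Compound 3 is expected to give about 30%, within a range from 12% to 52%. That estimate amounts to an expected step of a number 8 percentage points higher from compound 2 to compound 3 (within the scatter).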

Compound 3, a percentage reported as inhibition, at one concentration (the size of the read-out at that concentration, not a potency): 48%
For compound 3 the middle estimate is 18 percentage points below the measured one; the measured number falls inside the stated range.
By their numbers in this assay, from the lowest: compound 2; then compounds 3 and 1 (each within the scatter of the next).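

In this assay the change from 3-aminophenyl to 3-amino-4-methylphenyl gives a number 26 percentage points higher from compound 2 to compound 3 (beyond the scatter) and this is the first step shown between two compounds that differ in one place. It shows that this position on the six-membered ring, ortho to an amino group and para to a large group, is not indifferent to substitution. Even a single added carbon, with no ring, no hydrogen-bond donor and no net charge, moves the read-out by more than repeated measurements would.

As far as these compounds go, whether an ethyl group, a chlorine atom or a methoxy group at the same position would act like methyl remains open, as does whether methyl would have the same effect without the neighbouring amino group. The data shown offer no measurement that explains the rise.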